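Thromboxane synthase series: the nitrogen chain of compound 2

This account rests on a few compounds, and the source may have more. Where it says the series, first, only, none or still open, it means among the compounds named here.

Measured so far in an assay on isolated protein (Oryctolagus cuniculus) with Thromboxane-A synthase (Homo sapiens) as the target, tested at 1 uM; on this read-out lower numbers stand for less inhibition and higher numbers for more inhibition at the one concentration tested (going by the name of the read-out):
- compound 1 `CCCCn1nc(-c2cccnc2)c2ccccc2c1=O`: 91%
- compound 2 `CC(=O)Cn1nc(-c2cccnc2)c2ccccc2c1=O`: 13%
- compound 3 `COC(=O)c1ccc(Cn2nc(-c3cccnc3)c3ccccc3c2=O)cc1`: 95%

Compound 2 stands lowest of the three numbers in this assay, far beneath compound 1 and compound 3, both of which lie beyond the scatter above it. Going by the values given here, the only step at the same place is the one from compound 1 to compound 2, a number 78 percentage points lower from compound 1 to compound 2 (beyond the scatter), which shows how much the chain on the nitrogen can matter.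

Compound 4 `NCCn1nc(-c2cccnc2)c2ccccc2c1=O` is not yet measured. It differs from compound 2 in one place: aminomethyl in place of acetyl on a saturated chain carbon bound to an aromatic nitrogen. Among the compounds with values here, no measured pair bears directly on this exchange; the step from compound 1 to compound 2 only shows that changes here can be large in either direction.

Compound 4 is therefore expected to give 50%, within 10% to 90%. The expected step of a number 37 percentage points higher from compound 2 to compound 4 (beyond the scatter) is upward but very uncertain.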

Compound 4, a percentage reported as inhibition, at one concentration (the size of the read-out at that concentration, not a potency): 29%
Compound 4: the middle estimate sits 21 percentage points above what was measured; measured number inside the range.
By their numbers in this assay, from the lowest: compound 2; then compound 4; then compounds 1 and 3 (each within the scatter of the next).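

In this assay, a second replacement at the chain end also brings a large fall, with a number 62 percentage points lower from compound 1 to compound 4 (beyond the scatter) on the exchange of ethyl for amino, so the loss at this position is not confined to the acetyl group of compound 2. Exchanging acetyl for aminomethyl, that is 2-oxopropyl for 2-aminoethyl, gives only a modest gain, with a number 16 percentage points higher from compound 2 to compound 4 (beyond the scatter) as the step, and leaves compound 4 far from compound 1. No measurement at hand explains either step.

From the compounds shown here alone, it remains open whether a hydroxyl group or a carboxylic acid at the chain end would also stay low. Also open, going by these compounds, is whether a longer chain carrying the amine, or a dimethylamino group in its place, would move the number back towards that of compound 1.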